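The source may report more compounds than this note shows. Statements on the series, on what has been measured and on what is new or still open speak of the compounds shown alone.

Measured so far in the series:
compound 1, `CC(=O)SCCC(CCCCC(=O)Nc1ccccc1Cl)SC(C)=O`: 6.93%
compound 2, `CC(=O)SCCC(CCCCC(=O)Nc1cccc(Cl)c1)SC(C)=O`: 48.8%
compound 3, `O=C(CCCCC(CCSC(=O)c1ccccc1)SC(=O)c1ccccc1)Nc1ccccc1Cl`: "not active" (no number reported)

In a functional assay on KB cells (Homo sapiens) for inhibition, read by MTT assay, with a stated time of 24 h, tested at 100 ug/mL (a higher number here means more inhibition of growth at the concentration tested, a lower number less inhibition of growth), compound 1 gives 6.93%, and compound 2 gives 48.8%. The two share one core and differ in a single place, namely (3-chlorophenyl in place of 2-chlorophenyl on an amide-type nitrogen). Among the compounds with values here, that change produced a number 41.9 percentage points higher from compound 1 to compound 2 (beyond the scatter), which is the one counted step available.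

Compound 3 is reported in this assay as "not active" (no number reported), with no number attached; nothing more can be read from that entry than that it falls on the inactive side. How the core of compound 3 differs from the core of compound 1 is not broken down here.

Compound 4, `O=C(CCCCC(CCSC(=O)c1ccccc1)SC(=O)c1ccccc1)Nc1cccc(Cl)c1`, has not been measured. It stands to compound 3 exactly as compound 2 stands to compound 1: 3-chlorophenyl in place of 2-chlorophenyl on an amide-type nitrogen. The surroundings of the place are the same in words in both pairs, so this is the same kind of change carried onto the second core.

The expectation for compound 4 rests on a single precedent, the step from compound 1 to compound 2, which gave a number 41.9 percentage points higher from compound 1 to compound 2 (beyond the scatter) on the first core. The starting point on the second core is not known as a number, so the estimate is loose, and a report of no activity for compound 4 remains possible. Compound 4 is expected to give roughly 30%, with a likely range from 5% to 55%.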

Compound 4, percent growth inhibition at one concentration: "not active" (no number reported)
Compound 4 has no reported number here, and the estimate cannot be compared.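

In this assay compound 3 and compound 4 are both reported without a number, so no new step can be read between them. The compounds shown leave open whether 3-chlorophenyl in place of 2-chlorophenyl changes growth inhibition at all on the core of compound 3, and how far the step seen on the first core carries over. No measured evidence bears on this result.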